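Chain extension on the triazole substituent of compound 3

The source may hold more compounds than are shown below. What is called first, only, known or untested is meant among the compounds shown, and "the series" means these compounds.

Three analogues of a shared core have been run in an ADME assay on WI-38 cells (Homo sapiens) for cytotoxicity, read by MTT assay, with a stated time of 72 h; on this read-out higher numbers stand for weaker inhibition and lower numbers for stronger inhibition. Compound 1 `CN(C)CCn1cnnc1-c1cc(Oc2ccc(NC(=O)Nc3ccc(Cl)c(C(F)(F)F)c3)cc2F)ccn1` gives 3760 nM. Compound 2 `CN(C)CCn1cnnc1-c1cc(Oc2ccc(NC(=O)Nc3cccc(C(F)(F)F)c3)cc2F)ccn1` gives 11200 nM, and compound 3 `CN(C)CCn1cnnc1-c1cc(Oc2ccc(NC(=O)Nc3ccc(Cl)cc3Cl)cc2F)ccn1` gives 10400 nM. The steps among them are a 3.0-fold higher number from compound 1 to compound 2 (0.47 log units; beyond the scatter), a 2.8-fold higher number from compound 1 to compound 3 (0.44 log units; beyond the scatter) and a 1.1-fold lower number from compound 2 to compound 3 (0.03 log units; within the scatter). Compound 3 therefore stands second highest of the three numbers, within the scatter of compound 2 and beyond the scatter of compound 1, which gives the lowest number.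

Compound 4 `CN(C)CCCn1cnnc1-c1cc(Oc2ccc(NC(=O)Nc3ccc(Cl)cc3Cl)cc2F)ccn1` differs from compound 3 by (dimethylamino)methyl in place of dimethylamino on a saturated chain carbon, two bonds along the chain from an aromatic nitrogen. Among the measured compounds shown here, every measured step changes the aryl group on the amide-type nitrogen; none touches the chain on the triazole, so no measured step bears directly on this change. The one-atom chain extension is expected to leave the number within the scatter of compound 3, and the step from compound 3 to compound 4 is estimated as a 1.0-fold lower number from compound 3 to compound 4 (0.02 log units; within the scatter). Compound 4 is accordingly expected to give about 10000 nM in this assay, with a range from 4500 nM to 22000 nM.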

Compound 4, half-maximal inhibitory concentration: 3260 nM
Estimate against measurement, compound 4: 3.1-fold (0.49 log units) above; the whole stated range lies above it.
By their numbers in this assay, from the lowest: compounds 4 and 1 (each within the scatter of the next); then compounds 3 and 2 (each within the scatter of the next).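

In this assay, 3-(dimethylamino)propyl in place of 2-(dimethylamino)ethyl gives a 3.2-fold lower number from compound 3 to compound 4 (0.50 log units; beyond the scatter), so the chain on the triazole is a second place in the series where the number moves, alongside the aryl group on the amide-type nitrogen. The counts of hydrogen-bond donors and acceptors stay the same across this change, so those counts do not track the step. Nothing available accounts for the step.

On these data alone, the extension stands on the 2,4-dichlorophenyl compound alone, so whether it gives a similar step with the aryl groups of compound 1 and compound 2 remains open. Also open, as far as these compounds go, is whether a longer chain such as 4-(dimethylamino)butyl, or a morpholine in place of dimethylamino, would move the number further in the same direction.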